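Aryl ester in place of the amide at the carbonyl

The source may hold more compounds than are shown below. What is called first, only, known or untested is meant among the compounds shown, and "the series" means these compounds.

Measured compounds:
compound 1 `CCN(CC)CCCNC(=O)c1ccc(C(CC)(CC)c2ccc(OCC(O)C(C)(C)C)c(C)c2)n1CC` — 66 nM
compound 2 `C=CCN(C)C(=O)c1ccc(C(CC)(CC)c2ccc(OCC(O)C(C)(C)C)c(C)c2)n1CC` — 3950 nM

Within the data shown here, compound 2 gives the highest number of the two in an assay on HL-60 cells for agonist activity at vitamin D3 receptor (Homo sapiens), read by microscopy, with a stated time of 96 h; on this read-out lower numbers stand for an effect already at smaller amounts and higher numbers for an effect only at larger amounts of compound; its nearest neighbour is compound 1, and the only measured step, a 60-fold higher number from compound 1 to compound 2 (1.78 log units; beyond the scatter), shows how strongly the group on the carbonyl carbon moves this assay. Compound 3 `CCOC(=O)c1ccc(OC(=O)c2ccc(C(CC)(CC)c3ccc(OCC(O)C(C)(C)C)c(C)c3)n2CC)cc1` has not yet been measured. It differs from compound 2 in one place: 4-(ethoxycarbonyl)phenoxy in place of allyl(methyl)amino on a carbonyl carbon. Among the measured compounds shown here, no measured pair shows an ester replacing an amide here, so the step from compound 1 to compound 2 bears on it only by showing that changes at this carbonyl carbon can be large. The estimate therefore rests on that single step and is broad; the expected step is a 3.3-fold lower number from compound 2 to compound 3 (0.52 log units; beyond the scatter), toward a somewhat lower number than compound 2. For compound 3 the estimated value is 1200 nM, within a range of 150 nM to 10000 nM.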

Compound 3, half-maximal effective concentration: > 50000 nM
Compound 3: only a limit was reported; the forecaster's own chance of this, stated with the estimate: 10%; at least 41-fold (1.61 log units) between middle value and limit.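

In this assay compound 3 carries only a limit, not a number: the limit of > 50000 nM in this assay, at which 1 of the 3 values shown sits.

Among these compounds, until now this carbonyl carbon had been seen only with amides, and replacing allyl(methyl)amino with 4-(ethoxycarbonyl)phenoxy gives an at least 12-fold higher number from compound 2 to compound 3 (1.10 log units; beyond the scatter). Set against the better amide, the same ester gives an at least 750-fold higher number from compound 1 to compound 3 (2.87 log units; beyond the scatter), so it lies beyond the scatter on the high side of both amides, including compound 2, which already had the higher number of the two.

The compounds shown do not separate the ester link from the aromatic ring and its ethoxycarbonyl group as the source of this step. A plain ethyl ester, a free carboxylic acid, or an amide carrying the same 4-(ethoxycarbonyl)phenyl group on its nitrogen at this carbonyl carbon would bear on that question.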